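Swapping the Aryl Group on the Carbonyl of Compound 2

This account rests on a few compounds, and the source may have more. Where it says the series, first, only, none or still open, it means among the compounds named here.

Compound 2 `O=C(/C=C/c1ccc2c(c1)B(O)OC2)c1ccccc1O` stands highest of the two numbers in a functional assay on HCT-116 cells (Homo sapiens) for cytotoxicity, read by MTT assay, with a stated time of 48 h (on this read-out lower numbers stand for stronger inhibition and higher numbers for weaker inhibition), giving 77900 nM, while compound 1 `O=C(/C=C/c1ccc2c(c1)B(O)OC2)c1ccc(I)cc1` gives 11600 nM. Among the compounds with values here, the only measured step, a 6.7-fold higher number from compound 1 to compound 2 (0.83 log units; beyond the scatter), concerns the same place. Compound 3 `Nc1cccc(C(=O)/C=C/c2ccc3c(c2)B(O)OC3)c1` differs from compound 2 by 3-aminophenyl in place of 2-hydroxyphenyl on a carbonyl carbon. Within the data shown here, no measured step swaps these two groups, so the step from compound 1 offers only a rough sense of how far this place can move the number. Compound 3 is expected to give a lower number than compound 2, a step of roughly a 2.6-fold lower number from compound 2 to compound 3 (0.41 log units; beyond the scatter), with wide uncertainty. The estimate for compound 3 is 30000 nM, ranging from 8000 nM to 100000 nM.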

Compound 3, half-maximal inhibitory concentration: 4500 nM
Estimate against measurement, compound 3: 6.7-fold (0.82 log units) above, outside the stated range (below it).
By their numbers in this assay, from the lowest: compound 3; then compound 1; then compound 2.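

In this assay, 3-aminophenyl in place of 2-hydroxyphenyl gives a 17-fold lower number from compound 2 to compound 3 (1.24 log units; beyond the scatter) and so shows that this position can move the number further than the earlier pair did, even though the two groups match in heavy atoms, donors and acceptors. Replacing 4-iodophenyl with 3-aminophenyl also gives a 2.6-fold lower number from compound 1 to compound 3 (0.41 log units; beyond the scatter) and places compound 3 lowest of the three. Nothing shown accounts for these shifts. Going by these compounds, whether the gain belongs to the amine itself or to its place on the ring stays open, as does what a dimethylamino group or a carboxylic acid would give here.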